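Moving the amino group of compound 2

The source may hold more compounds than are shown below. What is called first, only, known or untested is meant among the compounds shown, and "the series" means these compounds.

In a functional assay on DU-145 cells (Homo sapiens) for cytotoxicity, read by trypan blue exclusion, with a stated time of 96 h (a lower number here means a stronger inhibitor, a higher number a weaker inhibitor), compound 1 `COc1cc(OC)c(/C=C/S(=O)(=O)Cc2cc(N)ccc2OC)c(OC)c1` gives 7500 nM while compound 2 `COc1cc(OC)c(/C=C/S(=O)(=O)Cc2ccc(Cl)c(N)c2)c(OC)c1` gives 10 nM and holds the lower of the two numbers. Compound 3 `COc1cc(OC)c(/C=C/S(=O)(=O)Cc2ccc(Cl)cc2N)c(OC)c1` carries 2-amino-4-chlorophenyl in place of 3-amino-4-chlorophenyl on a saturated chain carbon bound to a sulfonyl sulfur on a saturated chain carbon bound to a sulfonyl sulfur. Among the measured compounds shown here, the one measured step of a 750-fold lower number from compound 1 to compound 2 (2.88 log units; beyond the scatter) exchanged the group at this same place and was large, though a single pair fixes little. A sizeable move toward a higher number is therefore expected in this assay and is estimated as a 20-fold higher number from compound 2 to compound 3 (1.30 log units; beyond the scatter) for now. For compound 3 the expected value is 200 nM with an estimated range of 20 nM to 2000 nM.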

Compound 3, half-maximal inhibitory concentration: 2500 nM
Beside the measured number, compound 3's estimate is 13-fold (1.10 log units) below it; measured number above the stated range.
By their numbers in this assay, from the lowest: compound 2; then compound 3; then compound 1.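

In this assay, the amino group's placement alone proves decisive at this place, with a 250-fold higher number from compound 2 to compound 3 (2.40 log units; beyond the scatter), even though the groups that leave and enter have the same atoms. The advantage over 5-amino-2-methoxyphenyl also shrinks to a 3.0-fold lower number from compound 1 to compound 3 (0.48 log units; beyond the scatter), so the earlier large gain belongs to 3-amino-4-chlorophenyl specifically and not to every amino-chlorophenyl group. No measurement available here accounts for this difference. Going by these compounds, it remains open how a hydroxyl or an acetamide group would fare in place of the amino group of 3-amino-4-chlorophenyl, and whether a fluorine could stand in for its chlorine.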